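The source may report more compounds than this note shows. Statements on the series, on what has been measured and on what is new or still open speak of the compounds shown alone.

Measured compounds:
compound 1 `COc1ccc(OC)c(/C=N/NC(=O)Nc2ccc(Oc3ccnc(-c4nncn4CCN(C)C)c3)c(F)c2)c1`: 1510 nM in a functional assay on MKN-45 cells (Homo sapiens) for cytotoxicity, read by MTT assay, with a stated time of 72 h; on this read-out higher numbers stand for weaker inhibition and lower numbers for stronger inhibition
compound 2 `COc1cc(/C=N/NC(=O)Nc2ccc(Oc3ccnc(-c4nncn4CCN(C)C)c3)c(F)c2)cc(OC)c1OC`: 2900 nM in this assay

Among the measured compounds shown here, compound 2 gives the higher of the two numbers measured so far, but its nearest neighbour compound 1 differs from it by a 1.9-fold higher number from compound 1 to compound 2 (0.28 log units; within the scatter), a gap within the scatter, so the two are not told apart by these values. Both share the same core and differ only in the aromatic group attached to the carbon that carries a double bond to nitrogen.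

Compound 3 `CN(C)CCn1cnnc1-c1cc(Oc2ccc(NC(=O)N/N=C/c3cc(Br)c(O)c(Br)c3)cc2F)ccn1` is the next member of the series and has not yet been measured. It differs from compound 2 in the same place: 3,5-dibromo-4-hydroxyphenyl in place of 3,4,5-trimethoxyphenyl on a carbon with a double bond to nitrogen. For the measured compounds named here, the only measured step that bears on a change at this position is the one from compound 1 to compound 2, which exchanged one methoxy-bearing phenyl for another and stayed within the scatter. Going by the values given here, a change to a hydroxy- and bromine-bearing phenyl has no measured counterpart here, so the size of its effect is unknown. The expectation for compound 3 is therefore no step beyond the scatter, a 1.2-fold lower number from compound 2 to compound 3 (0.06 log units; within the scatter), with a wide range. In this assay compound 3 is estimated at 2500 nM, between 700 nM and 9000 nM.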

Compound 3, half-maximal inhibitory concentration: 4320 nM
Beside the measured number, compound 3's estimate is 1.7-fold (0.24 log units) below it; measured number inside the range.
By their numbers in this assay, from the lowest: compounds 1, 2 and 3 (each within the scatter of the next, the first and the last beyond it).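

In this assay this position now shows its first step beyond the scatter: 3,5-dibromo-4-hydroxyphenyl in place of 2,5-dimethoxyphenyl gives a 2.9-fold higher number from compound 1 to compound 3 (0.46 log units; beyond the scatter) and this step is modest, whereas the same group in place of 3,4,5-trimethoxyphenyl gives a 1.5-fold higher number from compound 2 to compound 3 (0.17 log units; within the scatter) and that step stays within the scatter. The new group, which has bromine atoms and a hydrogen-bond donor that neither methoxy-bearing phenyl has, can therefore be told apart from one of those two groups but not from the other, so this exchange shifts the number only modestly at most among the three compounds shown. No measurement here accounts for these numbers.

The two bromines and the hydroxy group enter together as one group, so their separate shares in the step remain unresolved, and a phenyl with only the hydroxy group or only the bromines would be needed to separate them. Also open, going by these compounds, is how the number would respond to a phenyl carrying an amine or a carboxylic acid at this position.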